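This account rests on a few compounds, and the source may have more. Where it says the series, first, only, none or still open, it means among the compounds named here.

Series notes. Compound 1 `Cn1cnnc1-c1cc(Oc2ccc(NC(=O)Nc3cccc(C(F)(F)F)c3)cc2F)ccn1` gives 1270 nM in a functional assay on NCI-H460 cells (Homo sapiens) for antiproliferative activity, read by MTT assay, with a stated time of 72 h (a lower number here means a stronger inhibitor, a higher number a weaker inhibitor), and stands, among the numbers reported, within the scatter of compound 2. Compound 2 `CN(C)CCn1cnnc1-c1cc(Oc2ccc(NC(=O)Nc3ccc(Cl)c(C(F)(F)F)c3)cc2F)ccn1` in this assay gives 1150 nM; compound 2 differs from compound 1 both in the chain on the aromatic nitrogen and in the aryl group, so these two values alone separate neither change. Compound 3 `CN(C)CCn1cnnc1-c1cc(Oc2ccc(NC(=O)Nc3ccccc3C(F)(F)F)cc2F)ccn1` in this assay reaches only a limit, > 50000 nM, (the limit of > 50000 nM in this assay, at which 1 of the 3 values shown sits). The step of an at least 43-fold higher number from compound 2 to compound 3 (1.63 log units; beyond the scatter) concerns the aryl group and not the chain, so it does not bear on the change considered here. Compound 4 `CCN(CC)CCn1cnnc1-c1cc(Oc2ccc(NC(=O)Nc3cccc(C(F)(F)F)c3)cc2F)ccn1` differs from compound 1 by (diethylamino)methyl in place of hydrogen on a saturated chain carbon bound to an aromatic nitrogen. Going by the values given here, no measured step isolates this change, and nothing points to a step beyond the scatter in this assay. Compound 4 is therefore expected to stay near compound 1, a 1.1-fold lower number from compound 1 to compound 4 (0.02 log units; within the scatter). Compound 4 is estimated at 1200 nM, with a range from 500 nM to 3000 nM.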

Compound 4, half-maximal inhibitory concentration: 9870 nM
The estimate for compound 4 lay 8.2-fold (0.92 log units) below the measured number, outside the stated range (above it).
By their numbers in this assay, from the lowest: compounds 2 and 1 (each within the scatter of the next); then compound 4. At a limit, above all of these: compound 3.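

In this assay, exchanging methyl for 2-(diethylamino)ethyl with the aryl group held fixed gives a 7.8-fold higher number from compound 1 to compound 4 (0.89 log units; beyond the scatter), so this position does not tolerate every chain equally. Going by these compounds alone, this is the first step that isolates the chain: compound 1 and compound 2 differ in both chain and aryl group, and the step from compound 2 to compound 3 concerns the aryl group alone. Nothing measured in the series bears on the reason for this step.

On these data alone, whether a dimethylamino group, a morpholine or a plain ethyl chain without an amine, carried on the aryl group of compound 1, would stay near compound 1 or near compound 4 remains open. Whether the step depends on the aryl group also remains open, as no pair shown makes the same chain change on a different aryl group.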